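The source may hold more compounds than are shown below. What is called first, only, known or untested is meant among the compounds shown, and "the series" means these compounds.

Measured so far in a functional assay on HepG2 cells (Homo sapiens) for antiproliferative activity, read by CCK-8 assay, with a stated time of 48 h; on this read-out lower numbers stand for stronger inhibition and higher numbers for weaker inhibition
- compound 1 `COc1ccc(/C=C\c2cc(OC)c(OC)c(OC)c2)cc1OCc1ccc(CNC(C)(C)C(=O)O)cc1` gives 6500 nM
- compound 2 `COc1ccc(/C=C\c2cc(OC)c(OC)c(OC)c2)cc1OCc1ccc(CN[C@H](C(=O)O)[C@H](C)O)cc1` gives > 10000 nM
- compound 3 `COc1ccc(/C=C\c2cc(OC)c(OC)c(OC)c2)cc1OCc1ccc(CN2CCCCC2C(=O)NCCNC(=O)OC(C)(C)C)cc1` gives 1100 nM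

Compound 2 gives > 10000 nM as a limit of the assay and not a number. Compound 4 (`COc1ccc(/C=C\c2cc(OC)c(OC)c(OC)c2)cc1OCc1ccc(CNCCN(C)C)cc1`) differs from compound 2 (2-(dimethylamino)ethyl in place of 1-carboxy-2-hydroxypropyl on an amine nitrogen) by having 2-(dimethylamino)ethyl in place of 1-carboxy-2-hydroxypropyl on an amine nitrogen. Within the data shown here, the one measured step on such a nitrogen (an at least 1.5-fold higher number from compound 1 to compound 2 (0.18 log units; that floor lies within the scatter)) exchanges one carboxy-bearing group for another and gives no size for this change. Compound 3 gives 1100 nM with no free carboxy group in its side chain, so a lower number in this assay is expected here, of uncertain size. The expected move (an at least 4.0-fold lower number from compound 2 to compound 4 (0.60 log units; beyond the scatter)) is downward. For compound 4 the estimated value is 2500 nM with an expected range from 600 nM to 9000 nM on present data.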

Compound 4, half-maximal inhibitory concentration: 4400 nM
Estimate against measurement, compound 4: 1.8-fold (0.25 log units) below, and the stated range covers the measured number.
By their numbers in this assay, from the lowest: compound 3; then compounds 4 and 1 (each within the scatter of the next). At a limit, above all of these: compound 2.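

In this assay, a side chain on this amine nitrogen without any carboxy group still gives a measured number: an at least 2.2-fold lower number from compound 2 to compound 4 (0.35 log units; beyond the scatter). Compound 2 gives > 10000 nM, which is a limit of the assay and not a number, and the step from it has only a lower bound: the limit of > 10000 nM in this assay, at which 1 of the 4 values shown sits. Against 1-carboxy-1-methylethyl, however, 2-(dimethylamino)ethyl shows no change beyond the scatter: a 1.5-fold lower number from compound 1 to compound 4 (0.17 log units; within the scatter).

As far as these compounds go, the true size of the step from compound 2 remains open. Also open, from the compounds shown here alone, is how a longer chain ending in a dimethylamino group, or a chain ending in morpholine, would read on this nitrogen.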